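The source may report more compounds than this note shows. Statements on the series, on what has been measured and on what is new or still open speak of the compounds shown alone.

Compound 1 `COc1ccc(C(=O)/C=C/c2cc3ccccc3[nH]c2=O)cc1` gives 45500 nM in an ADME assay on SF-539 cells (Homo sapiens) for cytotoxicity, read by sulforhodamine B assay, with a stated time of 24 h; a lower number here means that less compound is tolerated, a higher number that more compound is tolerated.
Compound 2 `O=C(/C=C/c1cc2ccccc2[nH]c1=O)c1ccc(O)cc1` gives 61700 nM in this assay.

Of these two numbers, compound 2 carries the larger one, although the step of a 1.4-fold higher number from compound 1 to compound 2 (0.13 log units; within the scatter) lies within the scatter, so the two compounds cannot be told apart. Compound 3 `O=C(/C=C/c1cc2ccccc2[nH]c1=O)c1ccc(Cl)cc1` differs from compound 2 by chloro in place of hydroxy on an aromatic carbon. Among the measured compounds shown here, no measured step exchanges these groups; the only known step, a 1.4-fold higher number from compound 1 to compound 2 (0.13 log units; within the scatter), concerns a different change and gives no guide. In this assay no step beyond the scatter is therefore expected. Compound 3 is estimated at 45000 nM, between 20000 nM and 100000 nM, an expected step of a 1.4-fold lower number from compound 2 to compound 3 (0.14 log units; within the scatter).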

Compound 3, concentration lethal to 50% of the cells: 74200 nM
Compound 3: middle estimate off by 1.6-fold (0.22 log units), on the low side; measured number inside the range.
By their numbers in this assay, from the lowest: compounds 1, 2 and 3 (each within the scatter of the next).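

In this assay, the change from 4-hydroxyphenyl to 4-chlorophenyl stays within the scatter (a 1.2-fold higher number from compound 2 to compound 3 (0.08 log units; within the scatter)), and so does chloro in place of methoxy (a 1.6-fold higher number from compound 1 to compound 3 (0.21 log units; within the scatter)). Among the compounds shown here, this position now carries a group without oxygen and without hydrogen-bond donors or acceptors, where the earlier pair offered only hydroxy and methoxy, and still no step goes beyond the scatter. No evidence is available that bears on this result. On these data alone, whether an amine or a carboxylic acid on this carbon would give a step beyond the scatter stays open. So does whether these three groups would remain within the scatter of one another on a different core.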